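The compounds below may be only part of what the source reports. "The series", "measured", "known", "first", "only" and "open" are said of these compounds alone.

Three selenium-containing compounds have been tested in a functional assay on HT-29 cells (Homo sapiens) for cytotoxicity, read by MTT assay, with a stated time of 72 h (a higher number here means that more compound is tolerated, a lower number that less compound is tolerated), and a fourth is still to be measured. Compound 1 `C[Se]/C(=N\C(=O)c1cccs1)NC(=O)c1cccs1` reaches only the limit of the assay, > 100000 nM. Compound 2 `O=C(/N=C(/NC(=O)c1cccs1)[Se]Cc1ccccc1)c1cccs1` likewise gives only a limit, > 100000 nM. Between them stands the change (hydrogen in place of phenyl on a saturated chain carbon bound to a selenium atom), and the step that the two limits leave unreadable from compound 2 to compound 1 cannot be read because of the limit of > 100000 nM in this assay, at which 3 of the 3 values shown sit. Compound 3 `O=C(/N=C(/NC(=O)c1csc([N+](=O)[O-])c1)[Se]Cc1ccccc1)c1csc([N+](=O)[O-])c1` also stops at a limit, > 100000 nM. The difference between the cores of compound 2 and compound 3 is not broken down here. Compound 4 `C[Se]/C(=N\C(=O)c1csc([N+](=O)[O-])c1)NC(=O)c1csc([N+](=O)[O-])c1` carries the same change, (hydrogen in place of phenyl on a saturated chain carbon bound to a selenium atom), made on the core of compound 3. The step that the limit leaves unreadable from compound 3 to compound 4 is expected to be small, since both compound 2 and compound 1 sit at the limit of > 100000 nM in this assay, at which 3 of the 3 values shown sit. Compound 4 is therefore estimated at 150000 nM in this assay, most likely again only a limit, somewhere between 60000 nM and 400000 nM.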

Compound 4, concentration lethal to 50% of the cells: > 100000 nM
Compound 4 was reported as a limit; the forecaster's own chance of this, stated with the estimate: 85%; the middle value lies beyond the limit too.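

No step can be read between compound 3 and compound 4, because both stop at a limit: the limit of > 100000 nM in this assay, at which 4 of the 4 values shown sit.

The compounds shown leave open whether changing benzyl to methyl makes any difference in this assay, and what value any of these four compounds would actually reach there.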